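The source may report more compounds than this note shows. Statements on the series, on what has been measured and on what is new or still open speak of the compounds shown alone.

Compound 1: `O=C(NCCNS(=O)(=O)c1ccc(-c2ccccc2OCc2cccc(O)c2)s1)Nc1cc(C(F)(F)F)cc(C(F)(F)F)c1` gives 17300 nM in a functional assay on HeLa cells (Homo sapiens) for inhibition, read by CCK-8 assay, with a stated time of 48 h; a higher number here means a weaker inhibitor, a lower number a stronger inhibitor.
Compound 2: `Cc1cc(C)cc(NC(=O)NCCNS(=O)(=O)c2ccc(-c3ccccc3OCc3cccc(O)c3)s2)c1` reaches only a limit of the assay, > 20000 nM, in this assay.
Compound 3: `Nc1ccc(Oc2ccccc2-c2ccc(S(=O)(=O)NCCNC(=O)Nc3cc(C(F)(F)F)cc(C(F)(F)F)c3)s2)cc1` reaches only a limit of the assay, > 20000 nM, in this assay.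

The series carries one shared core with a urea on an aryl group at one end and an aryl ether at the other. Compound 1 and compound 2 differ in the aryl group on the urea; the difference between these two cores is not broken down here.

From compound 1 to compound 3 the change is 4-aminophenyl in place of 3-hydroxybenzyl on an oxygen on an aromatic ring. The step it made is an at least 1.1-fold higher number from compound 1 to compound 3 (0.06 log units; that floor lies within the scatter). The value of compound 3 is a limit, so the step is itself only a floor, and the limit of > 20000 nM in this assay, at which 2 of the 3 values shown sit, is where two of the three values sit.

The unmeasured compound 4, `Cc1cc(C)cc(NC(=O)NCCNS(=O)(=O)c2ccc(-c3ccccc3Oc3ccc(N)cc3)s2)c1`, is built from compound 2 by the same change: 4-aminophenyl in place of 3-hydroxybenzyl on an oxygen on an aromatic ring. The place line reads word for word as in the pair compound 1 to compound 3, so this is the same change.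

For compound 2 only a limit is known. The same change on compound 1 gave no gain, and the step from compound 1 to compound 3 is an at least 1.1-fold higher number from compound 1 to compound 3 (0.06 log units; that floor lies within the scatter). Against that background the expected step is a step that the limit leaves unreadable from compound 2 to compound 4. Compound 4 is therefore expected at about 30000 nM in this assay, with a range of 15000 nM to 80000 nM, and most likely the assay will again report only a limit rather than a number.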

Compound 4, half-maximal inhibitory concentration: > 20000 nM
Compound 4 gave a limit, no number (the forecaster's own chance of this, stated with the estimate: 85%); the middle value lies beyond the limit too.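

In this assay compound 4 gives > 20000 nM, a limit of the assay. Compound 2 also stands at a limit, so no step can be read between compound 2 and compound 4. Left open is whether 4-aminophenyl in place of 3-hydroxybenzyl shifts the read-out at all with either aryl group on the urea, as most values shown stop at one point: the limit of > 20000 nM in this assay, at which 3 of the 4 values shown sit.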